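From methoxy to acetoxy in compound 1

The compounds below may be only part of what the source reports. "The series", "measured", "known", "first", "only" and "open" are said of these compounds alone.

In a functional assay for inhibition, with Rattus norvegicus as the target (a higher number here means a weaker inhibitor, a lower number a stronger inhibitor), compound 1 `COc1c(C)c(C)c2c(c1C)CCC(C)(/C=[N+](\[O-])C(C)(C)C)O2` gives 2940000 nM, the highest number of the three measured and so the weakest inhibitor among them. Compound 3 `COc1c(C)c(C)c2c(c1C)CCC(C)(/C=[N+](\[O-])C1CC1)O2` gives 296000 nM, and compound 2 `Cc1c(C)c2c(c(C)c1O)CCC(C)(/C=[N+](\[O-])C1CC1)O2` gives 6000 nM. The unmeasured compound 4 `CC(=O)Oc1c(C)c(C)c2c(c1C)CCC(C)(/C=[N+](\[O-])C(C)(C)C)O2` keeps the tert-butyl of compound 1 and differs at one place: acetyl in place of methyl on an oxygen on an aromatic ring. This places acetyl in place of methyl on an oxygen on an aromatic ring.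

For the measured compounds named here, no measured step makes this exchange. The closest is at the same oxygen, where methyl in place of hydrogen gives a large step, a 49-fold higher number from compound 2 to compound 3 (1.69 log units; beyond the scatter). The modest step of a 9.9-fold lower number from compound 1 to compound 3 (1.00 log units; beyond the scatter) concerns the group on the double-bonded nitrogen, which does not change here, but it suggests that the tert-butyl series sits at higher numbers. The data do not show whether acetyl on that oxygen behaves more like methyl or like hydrogen. A lower number is therefore expected, by a step smaller than a 49-fold higher number from compound 2 to compound 3 (1.69 log units; beyond the scatter), as the oxygen still carries a group. The expected change is a 9.8-fold lower number from compound 1 to compound 4 (0.99 log units; beyond the scatter). For compound 4 the estimated value is 300000 nM, with an expected range of 40000 nM to 2000000 nM.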

Compound 4, half-maximal inhibitory concentration: 895000 nM
Compound 4: middle estimate off by 3.0-fold (0.47 log units), on the low side; measured number inside the range.
By their numbers in this assay, from the lowest: compound 2; then compound 3; then compound 4; then compound 1.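

In this assay, the oxygen on the aromatic ring proves sensitive to more than the presence or absence of a methyl: with the tert-butyl group held constant, acetyl in place of methyl gives a 3.3-fold lower number from compound 1 to compound 4 (0.52 log units; beyond the scatter). This modest step runs in the same direction as the change from methyl to hydrogen on that oxygen in the cyclopropyl compounds, which is large when read as a 49-fold higher number from compound 2 to compound 3 (1.69 log units; beyond the scatter) with the direction turned round, so among the compounds shown, methoxy carries the highest number in each pair that changes at this oxygen. Nothing available explains why acetoxy gives the lower number, and no supporting measurement bears on the result.

The compounds shown leave open how acetoxy compares with a free hydroxy on the tert-butyl compounds, and whether acetyl would give a step of similar size alongside the cyclopropyl group on the double-bonded nitrogen. They also leave open whether a longer acyl chain such as butanoyl, or a benzoyl group, on the same oxygen would lower the number further or raise it.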